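The source may hold more compounds than are shown below. What is called first, only, known or untested is meant among the compounds shown, and "the series" means these compounds.

Measured compounds and their values:

Compound 1 `N/C(=N\NC(=S)N1CCOCC1)c1ccccn1` gives 19.3% in a functional assay on A-375 cells (Homo sapiens) for cytotoxicity, read by MTT assay, with a stated time of 72 h, tested at 3 uM; a higher number here means more inhibition of growth at the concentration tested, a lower number less inhibition of growth.
Compound 2 `Cc1ccnc(/C(N)=N/NC(=S)N2CCN(c3ccccn3)CC2)c1` gives 74.8% in this assay.
Compound 3 `Cc1cccc(/C(N)=N/NC(=S)N2CCOCC2)n1` gives 34.7% in this assay.

Compound 2 stands highest of the three, and its gaps to compound 3 and compound 1 both lie beyond the scatter. Compound 3 and compound 1 share one core and differ only by hydrogen in place of methyl on an aromatic carbon, and that change made the step of a number 15.4 percentage points lower from compound 3 to compound 1 (beyond the scatter). The core of compound 2 differs from that of compound 3, but the difference between the two cores is not broken down here.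

Compound 4 `N/C(=N\NC(=S)N1CCN(c2ccccn2)CC1)c1ccccn1` is not yet measured. It differs from compound 2 by hydrogen in place of methyl on an aromatic carbon. Among the measured compounds shown here, this is the same kind of change as the one from compound 3 to compound 1, but the surroundings differ: in compound 3 the methyl sits next to the ring nitrogen, while in compound 2 it sits opposite the ring nitrogen. Because a number 15.4 percentage points lower from compound 3 to compound 1 (beyond the scatter) was a modest drop, a step of similar size is expected, a number 14.8 percentage points lower from compound 2 to compound 4 (beyond the scatter). Compound 4 is therefore estimated at 60% in this assay, most likely between 45% and 75%.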

Compound 4, percent growth inhibition at one concentration: 73.7%
Beside the measured number, compound 4's estimate is 13.7 percentage points below it, and the stated range covers the measured number.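

Going from 4-methylpyridin-2-yl to pyridin-2-yl in this assay gave a number 1.1 percentage points lower from compound 2 to compound 4 (within the scatter), so on this core the two compounds cannot be told apart and the methyl shows no readable contribution. The same written change therefore did not carry over with the same size from one core to the other: the same change on two cores in this assay, a number 15.4 percentage points lower (beyond the scatter) from compound 3 to compound 1 and a number 1.1 percentage points lower (within the scatter) from compound 2 to compound 4, 14.3 percentage points apart, beyond the scatter of two such steps This does not show why the two steps differ, since the two pairs differ in the rest of the core and also in where the methyl sits on the ring, and two pairs cannot separate these two differences or predict the step on a third core.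

The compounds shown have only methyl or hydrogen at these ring positions, so the outcome with an ethyl group, a methoxy group or a chlorine atom remains open. Also open, from the compounds shown here alone, is what a methyl placed as in compound 3 would do on the core of compound 2, and what one placed as in compound 2 would do on the core of compound 1.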